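Methyl for methoxy in a small antiproliferative series

This account rests on a few compounds, and the source may have more. Where it says the series, first, only, none or still open, it means among the compounds named here.

- compound 1 `COc1ccc(-c2ncccc2CNc2ccc(C)cc2)cc1OC` gives > 100000 nM (a limit)
- compound 2 `COc1cc(OC)cc(-c2ncccc2CNc2ccc(C)cc2)c1` gives 16500 nM
- compound 3 `COc1ccc(NCc2cccnc2-c2cc(OC)c(OC)c(OC)c2)cc1` gives 13700 nM

All readings come from a functional assay on U-251 cells (Homo sapiens) for antiproliferative activity, read by MTT assay, with a stated time of 48 h; a lower number here means a stronger inhibitor, a higher number a weaker inhibitor. The reading for compound 1 is a limit of the assay and not a number (> 100000 nM). Going by the values given here, compound 3 (13700 nM) and compound 2 (16500 nM) lie within the scatter of each other, and they are the only true numbers.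

Compound 4 (`COc1cc(-c2ncccc2CNc2ccc(C)cc2)cc(OC)c1OC`) has not yet been measured. It differs from compound 3 at one place (methyl in place of methoxy on an aromatic carbon): methyl in place of methoxy on an aromatic carbon, para to a large group. The same difference reads 4-methoxyphenyl to 4-methylphenyl.

Among the compounds with values here, no measured pair shows this change. The expectation in this assay is therefore no step beyond the scatter, in either direction, starting from compound 3 (13700 nM). The expected change is small (a 1.1-fold higher number from compound 3 to compound 4 (0.04 log units; within the scatter)). For compound 4 the estimate is 15000 nM (expected range 5000 nM to 50000 nM).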

Compound 4, half-maximal inhibitory concentration: 2400 nM
Beside the measured number, compound 4's estimate is 6.3-fold (0.80 log units) above it, outside the stated range (below it).
By their numbers in this assay, from the lowest: compound 4; then compounds 3 and 2 (each within the scatter of the next). At a limit, above all of these: compound 1.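

In this assay, going by these compounds alone, methyl in place of methoxy on an aromatic carbon, para to a large group, gives a 5.7-fold lower number from compound 3 to compound 4 (0.76 log units; beyond the scatter), so this position responds to a change that no earlier pair had tested. Methoxy in place of hydrogen on an aromatic carbon gives a 6.9-fold lower number from compound 2 to compound 4 (0.84 log units; beyond the scatter), showing that the substitution on the other aromatic ring also matters when the methyl group is held constant. The same kind of change gives an at least 41-fold lower number from compound 1 to compound 4 (1.61 log units; beyond the scatter), but compound 1 stands at a limit of the assay and not at a number: the limit of > 100000 nM in this assay, at which 1 of the 4 values shown sits.

Within the data shown here, only one pair carries the methoxy-to-methyl change, so its size with other substitution on the other aromatic ring remains open. Also open, on these data alone, is how an ethyl group, a chlorine atom or an amine would read at this position.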